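This account rests on a few compounds, and the source may have more. Where it says the series, first, only, none or still open, it means among the compounds named here.

Measured compounds:
compound 1, `COc1ccc(C(=O)/C=C/c2ccc(F)cc2)c2c1C=CC(C)(C)O2`: > 10000 nM
compound 2, `COc1ccc(C(=O)/C=C/c2ccc(Br)cc2)c2c1C=CC(C)(C)O2`: > 10000 nM
compound 3, `CCN(CC)c1ccc(/C=C/C(=O)c2ccc(OC)c3c2OC(C)(C)C=C3)cc1`: 610 nM

In a functional assay on SK-OV-3 cells (Homo sapiens) for antiproliferative activity, read by MTT assay, with a stated time of 24 h (on this read-out higher numbers stand for weaker inhibition and lower numbers for stronger inhibition), compound 1 gives > 10000 nM, which is a limit of the assay rather than a number. Compound 2 likewise gives > 10000 nM, also a limit. Within the data shown here, compound 3 is therefore the only one of the three with a real number, and compound 3 gives 610 nM as the sole measured value. The step that the two limits leave unreadable from compound 1 to compound 2 cannot be read in size, since both ends sit at the limit (the limit of > 10000 nM in this assay, at which 2 of the 3 values shown sit). The steps of an at least 16-fold lower number from compound 1 to compound 3 (1.21 log units; beyond the scatter) and an at least 16-fold lower number from compound 2 to compound 3 (1.21 log units; beyond the scatter) are both large and both point toward a lower number when a diethylamino group replaces a halogen.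

Compound 4, `COc1ccc(C(=O)/C=C/c2ccc(N3CCCC3)cc2)c2c1C=CC(C)(C)O2`, differs from compound 3 by pyrrolidin-1-yl in place of diethylamino on an aromatic carbon. Among the measured compounds shown here, none of the measured steps exchanges one amino group for another, so they bear on this change only indirectly: they show that an amino group at this position goes with a much lower number than either halogen. The change from diethylamino to pyrrolidin-1-yl keeps the nitrogen and the atom count, so the expected step of a 1.2-fold lower number from compound 3 to compound 4 (0.09 log units; within the scatter) is small and within the scatter. Compound 4 is thus estimated at 500 nM, with a range from 200 nM to 1500 nM.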

Compound 4, half-maximal inhibitory concentration: 7370 nM
Compound 4: the middle estimate sits 15-fold (1.17 log units) below what was measured; the measured number lies above the stated range.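

In this assay, this position responds to the form of the amino group and not merely to the presence of one: the nitrogen and the count of heavy atoms stay the same, yet closing the two ethyl chains of diethylamino into the pyrrolidin-1-yl ring gives a 12-fold higher number from compound 3 to compound 4 (1.08 log units; beyond the scatter). The earlier steps linked an amino group here with a much lower number than either halogen, but compound 4 does not secure that link, since the comparisons give an at least 1.3-fold lower number from compound 2 to compound 4 (0.13 log units; that floor lies within the scatter) and an at least 1.3-fold lower number from compound 1 to compound 4 (0.13 log units; that floor lies within the scatter), so that diethylamino in compound 3 remains the one amino group shown with a step beyond the scatter. These two steps stay open-ended because compound 1 and compound 2 sit at a limit and not at a number: the limit of > 10000 nM in this assay, at which 2 of the 4 values shown sit.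

The compounds shown leave open whether the higher number of compound 4 belongs to the ring itself or to the loss of the ethyl chains, a question that a dimethylamino, dipropylamino, piperidin-1-yl or morpholin-4-yl group at the same place could help to settle. From the compounds shown here alone, it also remains open whether the gap between these two amino groups holds in other cell lines.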